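The compounds below may be only part of what the source reports. "The series", "measured", "known", "first", "only" and "open" are said of these compounds alone.

Compound 1 `COc1cc(C(=O)c2sc(-c3cccc([N+](=O)[O-])c3)cc2N)cc(OC)c1OC`: 7.5 nM
Compound 2 `COc1cc(C(=O)c2sc(-c3ccccc3)cc2N)cc(OC)c1OC`: 5.3 nM

The two measured compounds share one core and differ only on a six-membered aromatic ring. In a functional assay on MOLT-4 cells (Homo sapiens) for antiproliferative activity (a higher number here means a weaker inhibitor, a lower number a stronger inhibitor), compound 1 gives 7.5 nM and compound 2 gives 5.3 nM; the two numbers are separated by a 1.4-fold lower number from compound 1 to compound 2 (0.15 log units; within the scatter), so neither stands apart from the other. Compound 3 `CCOc1ccc(-c2cc(N)c(C(=O)c3cc(OC)c(OC)c(OC)c3)s2)cc1` carries the change ethoxy in place of hydrogen on an aromatic carbon on that same ring. Going by the values given here, the only measured step also altered that ring and stayed within the scatter, which gives no ground to expect movement beyond the scatter here; the expected step is a 1.0-fold higher number from compound 2 to compound 3 (0.02 log units; within the scatter). Compound 3 is therefore estimated at 5.5 nM, in the range 2 nM to 15 nM.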

Compound 3, half-maximal inhibitory concentration: 240 nM
Estimate against measurement, compound 3: 44-fold (1.64 log units) below, and the stated range ends below it.
By their numbers in this assay, from the lowest: compounds 2 and 1 (each within the scatter of the next); then compound 3.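

In this assay, the ring's outer position is not indifferent to what it carries: ethoxy in place of hydrogen, para to a large group, brings a large loss (a 45-fold higher number from compound 2 to compound 3 (1.66 log units; beyond the scatter)). Exchanging 3-nitrophenyl for 4-ethoxyphenyl also brings a large loss (a 32-fold higher number from compound 1 to compound 3 (1.51 log units; beyond the scatter)), so a substituted ring does not by itself guarantee a low number. Nothing measured here accounts for this loss.

Still open, from the compounds shown here alone, is whether methoxy or an amine at that same place would keep the low number of compound 2. Going by these compounds, it is also open whether ethoxy elsewhere on the ring would bring the same loss.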